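This account rests on a few compounds, and the source may have more. Where it says the series, first, only, none or still open, it means among the compounds named here.

Measured compounds:
- Compound 1, `O=C(Nc1cc(Sc2ncn[nH]2)c(O)c2ccccc12)c1ccc2ccccc2c1`: > 100000 nM
- Compound 2, `O=C(Nc1cc(Sc2ncn[nH]2)c(O)c2ccccc12)c1cccc(Cl)c1`: 85600 nM

The study follows a series built on a shared core, varied at the carbonyl carbon of the amide. Among the measured compounds shown here, in a functional assay on PC-3 cells (Homo sapiens) for antiproliferative activity, read by MTT assay, with a stated time of 48 h (on this read-out lower numbers stand for stronger inhibition and higher numbers for weaker inhibition), compound 2 gives 85600 nM, the only plain number in the set. Compound 1 is different in kind: its value of > 100000 nM in this assay is a limit of the assay and not a number, as noted by the limit of > 100000 nM in this assay, at which 1 of the 2 values shown sits. For the measured compounds named here, the only step available between measured compounds is an at least 1.1-fold lower number from compound 1 to compound 2 (0.06 log units; that floor lies within the scatter), and it rests on one limit and one number, so it says little about the size of effects at this position.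

Compound 3, `O=C(/C=C/c1ccccc1)Nc1cc(Sc2ncn[nH]2)c(O)c2ccccc12`, has not been measured. Its change from compound 2 is 2-phenylethenyl in place of 3-chlorophenyl on a carbonyl carbon. Going by the values given here, no measured step covers this exact replacement; the one step that does bear on the position, from compound 1 to compound 2, was small and bounded by a limit. The number for compound 3 in this assay is therefore expected to stay close to that of compound 2, with wide uncertainty. The estimated step is a 1.2-fold lower number from compound 2 to compound 3 (0.09 log units; within the scatter). Compound 3 is estimated at 70000 nM, within a range from 25000 nM to 200000 nM.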

Compound 3, half-maximal inhibitory concentration: > 100000 nM
Compound 3: a limit, no number (the forecaster's own chance of this, stated with the estimate: 40%); middle value at least 1.4-fold (0.15 log units) from the limit.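

In this assay, compound 3, like compound 1, gives a limit of the assay and not a number: the limit of > 100000 nM in this assay, at which 2 of the 3 values shown sit.

Putting 2-phenylethenyl in place of 3-chlorophenyl on the carbonyl carbon gives an at least 1.1-fold higher number from compound 2 to compound 3 (0.06 log units; that floor lies within the scatter), so this change shows no measurable gain, and the limit leaves the true size of the step unknown. Compound 2 now stands as the only one of the three with a plain number, with both naphthalen-2-yl and 2-phenylethenyl at the limit, and the step between those two compounds cannot be read.

What the compounds shown leave open is whether any group on this carbonyl carbon can bring the number well down, for instance a short chain ending in an amine or a phenyl ring carrying a carboxylic acid. Also open, from the compounds shown here alone, is whether the chlorine in 3-chlorophenyl matters at all, which a plain phenyl on the same carbon would help to settle.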